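Iodo for bromo on the aryl group of compound 3

A few compounds are considered here, and "the series" means these few. Any claim that something is new, unique, unknown or untested is made for them only; others in the source may bear on it.

Values in a functional assay on B16 cells (Mus musculus) for cytotoxicity, read by CCK-8 assay, with a stated time of 24 h; on this read-out lower numbers stand for stronger inhibition and higher numbers for weaker inhibition:
- compound 1 `COc1ccccc1Oc1c(N)nc(-c2ccc(I)cc2)nc1Cl` gives 5400 nM
- compound 2 `COc1ccccc1Oc1c(N)nc(-c2cccc(F)c2)nc1OCCO` gives 20900 nM
- compound 3 `COc1ccccc1Oc1c(N)nc(-c2ccc(Br)cc2)nc1OCCO` gives 11800 nM

Compound 3 stands second highest of the three numbers in this assay. It lies within the scatter of compound 2, while compound 1 gives a lower number, a gap beyond the scatter.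

The next compound to read is compound 4 `COc1ccccc1Oc1c(N)nc(-c2ccc(I)cc2)nc1OCCO`, which has iodo in place of bromo on an aromatic carbon. Going by the values given here, the only measured step on this aryl group is a 1.8-fold lower number from compound 2 to compound 3 (0.25 log units; within the scatter), and it replaces 3-fluorophenyl with 4-bromophenyl. That step stays within the scatter, and it offers no sign of a large response to a change on this group. Compound 1 already carries the 4-iodophenyl group, but it also differs from compound 4 elsewhere on the shared core, so its value does not isolate the change from bromo to iodo. Among the compounds with values here, no measured pair isolates that change.

No step beyond the scatter is therefore expected, and the expected size is a 1.2-fold lower number from compound 3 to compound 4 (0.07 log units; within the scatter). The estimated value for compound 4 is 10000 nM, with an expected range from 5000 nM to 20000 nM.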

Compound 4, half-maximal inhibitory concentration: 19600 nM
The estimate for compound 4 lay 2.0-fold (0.29 log units) below the measured number; the measured number falls inside the stated range.
By their numbers in this assay, from the lowest: compound 1; then compounds 3, 4 and 2 (each within the scatter of the next).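

In this assay, the exchange of bromo for iodo is now isolated: a 1.7-fold higher number from compound 3 to compound 4 (0.22 log units; within the scatter), so with 2-hydroxyethoxy on the shared core, the change from 4-bromophenyl to 4-iodophenyl gives no readable difference. The wider aryl comparison reads the same way, with a 1.1-fold lower number from compound 2 to compound 4 (0.03 log units; within the scatter), and since the step from compound 2 to compound 3 is also within the scatter, 3-fluorophenyl, 4-bromophenyl and 4-iodophenyl cannot be told apart among these three compounds. Going by these compounds alone, the only step here that clears the scatter lies at the other place of variation, with 4-iodophenyl held constant: a 3.6-fold higher number from compound 1 to compound 4 (0.56 log units; beyond the scatter), for 2-hydroxyethoxy in place of chloro, so in these compounds the readable difference sits at that carbon and not on the aryl group.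

It remains open whether bromo and iodo would also read alike with chloro on the core, and how an amine or a carboxylic acid in place of chloro would compare with the two groups shown. No supporting measurement is available to explain any of these steps.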